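Swapping the carboxy-bearing ring in a weak antiproliferative series

A few compounds are considered here, and "the series" means these few. Any claim that something is new, unique, unknown or untested is made for them only; others in the source may bear on it.

Measured compounds:
- compound 1, `COc1ccc(/C=C\c2cc(OC)c(OC)c(OC)c2)cc1OCc1ccc(CN2CCCC[C@@H]2C(=O)O)cc1`: > 10000 nM
- compound 2, `COc1ccc(/C=C\c2cc(OC)c(OC)c(OC)c2)cc1OCc1ccc(CN2CCCCC2C(=O)O)cc1`: 14200 nM
- compound 3, `COc1ccc(/C=C\c2cc(OC)c(OC)c(OC)c2)cc1OCc1ccc(CN2CC[C@H](C(=O)O)C2)cc1`: > 10000 nM

In a functional assay on HeLa cells (Homo sapiens) for antiproliferative activity, read by CCK-8 assay, with a stated time of 48 h (a lower number here means a stronger inhibitor, a higher number a weaker inhibitor), compound 1 gives > 10000 nM, which is a limit of the assay and not a number. Compound 2 differs from it only in that the stereocentre at a saturated ring carbon is drawn without a configuration, and in this assay compound 2 gives 14200 nM, so the step that the limit leaves unreadable from compound 1 to compound 2 cannot be sized; the reason is the limit of > 10000 nM in this assay, at which 2 of the 3 values shown sit, and (the fact that one of compounds 1 and 2 is drawn with a defined configuration and the other without, at the place where they differ). Compound 3 gives > 10000 nM in this assay, again a limit. The step that the two limits leave unreadable from compound 1 to compound 3 is therefore unreadable, as is a step that the limit leaves unreadable from compound 2 to compound 3.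

Compound 4, `COc1ccc(/C=C\c2cc(OC)c(OC)c(OC)c2)cc1OCc1ccc(CN2CC[C@@H](C(=O)O)C2)cc1`, is not yet measured. It differs from compound 1 by 3-carboxypyrrolidin-1-yl in place of 2-carboxypiperidin-1-yl on a saturated chain carbon bound to an aromatic carbon. The measured steps that bear on this change, from compound 1 and from compound 2 to compound 3, are both unreadable because of the limit of > 10000 nM in this assay, at which 2 of the 3 values shown sit, and compound 3 already carries the 3-carboxypyrrolidin-1-yl group and sits at a limit. Nothing here points to a gain. Compound 4 is therefore expected to stay near the limit in this assay, with the step that the limit leaves unreadable from compound 1 to compound 4 expected to be no larger than the scatter. The estimate for compound 4 is 15000 nM, between 8000 nM and 40000 nM.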

Compound 4, half-maximal inhibitory concentration: 12800 nM
The estimate for compound 4 lay 1.2-fold (0.07 log units) above the measured number; the range from low to high includes it.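

In this assay the 3-carboxypyrrolidin-1-yl group can now be compared with 2-carboxypiperidin-1-yl on a saturated chain carbon bound to an aromatic carbon, and the result is a 1.1-fold lower number from compound 2 to compound 4 (0.05 log units; within the scatter). The five-membered and six-membered carboxy-bearing rings therefore cannot be told apart at this position, although the stereocentre of the piperidine ring in compound 2 is drawn without a configuration. The other steps that involve compound 4 cannot be read because compound 1 and compound 3 each carry a limit of the assay and not a number: the limit of > 10000 nM in this assay, at which 2 of the 4 values shown sit.

Whether the drawn configuration of the pyrrolidine ring matters stays open, since compound 3 carries only a limit and the comparison with compound 4 rests on a single configuration change: the fact that compounds 3 and 4 differ only in the configuration as drawn Every compound shown also keeps a carboxylic acid on the ring, so the compounds shown do not tell whether a methyl ester or a primary amide in its place would give a lower number in this assay.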